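The source may hold more compounds than are shown below. What is called first, only, known or untested is meant among the compounds shown, and "the series" means these compounds.

Working notes on the series. Of the compounds shown here, three built on a shared core have been measured in a functional assay on HeLa cells (Homo sapiens) for cytotoxicity, read by MTT assay; a lower number here means a stronger inhibitor, a higher number a weaker inhibitor. Compound 1 `CCOC(=O)C12C(=O)OCC=C1COC2c1ccccc1` gives 12800 nM, compound 2 `CCOC(=O)C12C(=O)OCC=C1COC2c1ccc(Cl)cc1` gives 118000 nM, and compound 3 `CCOC(=O)C12C(=O)OCC=C1COC2c1ccc(C(C)(C)C)cc1` gives 25400 nM. Compound 3 thus holds the second highest of the three numbers; the nearest number is reached by a 2.0-fold higher number from compound 1 to compound 3 (0.30 log units; within the scatter), the furthest by a 4.6-fold lower number from compound 2 to compound 3 (0.67 log units; beyond the scatter).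

The next compound, compound 4 `CCOC(=O)C12C(=O)OCC=C1COC2c1ccc(OC)cc1`, differs from compound 3 in one place: methoxy in place of tert-butyl on an aromatic carbon. All three measured steps alter the same aromatic carbon: a 9.2-fold higher number from compound 1 to compound 2 (0.96 log units; beyond the scatter), a 2.0-fold higher number from compound 1 to compound 3 (0.30 log units; within the scatter) and a 4.6-fold lower number from compound 2 to compound 3 (0.67 log units; beyond the scatter). Going by the values given here, none of them involves a methoxy group, so the present change has no direct counterpart. What the measured steps show is that swapping the group at this carbon has moved the number by a modest amount at most, and in both directions, with the tert-butyl compound and the unsubstituted compound lying within the scatter of each other. The expectation is therefore a small step, direction uncertain, with the possibility of a modest rise of the kind seen with chloro.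

Compound 4 is estimated at 25000 nM, with a range from 7000 nM to 90000 nM. This estimate corresponds to an expected 1.0-fold lower number from compound 3 to compound 4 (0.01 log units; within the scatter) in this assay.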

Compound 4, half-maximal inhibitory concentration: 18300 nM
Estimate against measurement, compound 4: 1.4-fold (0.14 log units) above; the measured number falls inside the stated range.
By their numbers in this assay, from the lowest: compounds 1, 4 and 3 (each within the scatter of the next); then compound 2.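

In this assay, methoxy joins hydrogen and tert-butyl among the groups at this aromatic carbon that stay together inside the scatter, with a 1.4-fold lower number from compound 3 to compound 4 (0.14 log units; within the scatter) and with a 1.4-fold higher number from compound 1 to compound 4 (0.16 log units; within the scatter) as the two readings that place it there. The exchange of tert-butyl for methoxy replaces 4 heavy atoms, all carbon, with 2 heavy atoms, one of them oxygen, and brings in a hydrogen-bond acceptor, yet this difference does not carry the number beyond the scatter. Chloro now stands apart from three groups instead of two, with a 6.4-fold lower number from compound 2 to compound 4 (0.81 log units; beyond the scatter) as the widest step yet seen to it from a group other than hydrogen, so among the compounds shown compound 2 alone departs at this position, and it gives the highest number of the four.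

Nothing available bears on why chloro departs from the other three groups. Still open, from the compounds shown here alone, is whether that departure belongs to chloro alone or would recur with bromo or fluoro at the same aromatic carbon, and whether an amine or a carboxylic acid there would stay with the other three groups or move beyond the scatter.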